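Replacing 2-chloro-6-methylphenyl with 3-bromophenyl in a cytotoxicity series

A few compounds are considered here, and "the series" means these few. Any claim that something is new, unique, unknown or untested is made for them only; others in the source may bear on it.

Measured in a functional assay on A549 cells (Homo sapiens) for cytotoxicity, read by MTT assay, with a stated time of 72 h; on this read-out higher numbers stand for weaker inhibition and lower numbers for stronger inhibition:
- Compound 1 `Cc1ccc(F)cc1NC(=O)CN1CCN(c2nnc(Cc3ccccc3)c3ccccc23)CC1`: "not active" (no number reported)
- Compound 2 `COc1ccc(NC(=O)CN2CCN(c3nnc(Cc4ccccc4)c4ccccc34)CC2)cc1OC`: "not active" (no number reported)
- Compound 3 `Cc1cccc(Cl)c1NC(=O)CN1CCN(c2nnc(Cc3ccccc3)c3ccccc23)CC1`: 7420 nM

Compound 3 is the only one of the three with a numerical result, which makes it the sole quantitative reference point in this small set. Compound 1 and compound 2 share its core but differ in the group on the amide-type nitrogen, and neither yielded a number. Among the measured compounds shown here, no step between two measured compounds can therefore be calculated.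

The next compound is compound 4 `O=C(CN1CCN(c2nnc(Cc3ccccc3)c3ccccc23)CC1)Nc1cccc(Br)c1`, which has not yet been measured. It carries 3-bromophenyl in place of 2-chloro-6-methylphenyl on an amide-type nitrogen.

Compound 1 at "not active" (no number reported) and compound 2 at "not active" (no number reported) suggest that a change of this group may not preserve measurable activity, so a small weakening is expected in this assay, as the estimated step of a 2.2-fold higher number from compound 3 to compound 4 (0.33 log units; beyond the scatter). A report without a number is also quite possible. For compound 4 the estimated value is 16000 nM, with an expected range of 5000 nM to 50000 nM.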

Compound 4, half-maximal inhibitory concentration: "not active" (no number reported)
Compound 4: no number reported, so the estimate cannot be set against anything.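

Among the compounds shown here, compound 4 gives "not active" (no number reported), so no step from compound 3 can be read. Nothing shown here offers an explanation for this result. The compounds shown leave open how the potency of compound 3 relates to that of compounds 1, 2 and 4, none of which has a number.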